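The source may hold more compounds than are shown below. What is called first, only, known or untested is meant among the compounds shown, and "the series" means these compounds.

Three compounds of the shared core of compound 2, which is `O=C(O)/C(S)=C/c1ccccc1Cl`, have been run through an assay on isolated protein for inhibition of Calpain-1 catalytic subunit (Sus scrofa), read by FRET; on this read-out lower numbers stand for stronger inhibition and higher numbers for weaker inhibition. In this assay compound 2 gives 11900 nM, the second highest of the three numbers. Its nearest neighbour is compound 1, `O=C(O)/C(S)=C/c1cccc(F)c1`, which in this assay gives 19000 nM; the gap between the two lies within the usual scatter of repeated measurements, so nothing separates them. Far away stands compound 3, `O=C(O)/C(S)=C/c1c[nH]c2ccc(I)cc12`, which in this assay gives 100 nM, a number lower by a margin well beyond the scatter.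

The step under consideration leads from compound 2 to compound 4, `O=C(O)/C(S)=C/c1ccccc1I`. The change is iodo in place of chloro on an aromatic carbon, on an aromatic carbon of a six-membered aromatic ring of carbon only, ortho to a group of 6 heavy atoms. For the measured compounds named here, no measured pair in this set shows what such an exchange does on this core, so the outcome cannot be read off directly. The closest hint is that compound 3, which carries an iodo group on a different core, gives 100 nM, but that comparison mixes several changes at once. Compound 4 is therefore expected to stay close to compound 2, with a step from compound 2 to compound 4 of about a 1.5-fold lower number from compound 2 to compound 4 (0.17 log units; within the scatter), a change not expected to exceed the scatter. Compound 4 is estimated at 8000 nM, within a range from 3000 nM to 25000 nM.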

Compound 4, half-maximal inhibitory concentration: 29600 nM
The estimate for compound 4 lay 3.7-fold (0.57 log units) below the measured number, and the stated range ends below it.
By their numbers in this assay, from the lowest: compound 3; then compounds 2, 1 and 4 (each within the scatter of the next, the first and the last beyond it).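

In this assay, iodo in place of chloro on an aromatic carbon, ortho to a group of 6 heavy atoms, gives a 2.5-fold higher number from compound 2 to compound 4 (0.40 log units; beyond the scatter). For the compounds shown here, this is the first pair in the set that differs in one place, and it shows that the exchange weakens inhibition at this position on the shared core: the step is modest but beyond the scatter, so the position does not tolerate the two halogens as equals. The measurements at hand offer no explanation for the direction or the size of this step.

What the compounds shown leave open is how a bromo group, a methoxy group or an amine would behave on this same aromatic carbon, and so whether the weakening seen with iodo belongs to a wider trend among groups at this position or to this one exchange alone. A single pair also cannot tell whether iodo in place of chloro would have the same effect elsewhere on the six-membered aromatic ring, or on a core with a different group in place of the carboxylic acid, such as an amide.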